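The source may report more compounds than this note shows. Statements on the series, on what has been measured and on what is new or still open speak of the compounds shown alone.

In an ADME assay on microsomes from liver (Homo sapiens) for metabolic stability, read by LC-MS, using NADPH, with a stated time of 15 min, tested at 1 uM (on this read-out lower numbers stand for slow clearance and higher numbers for fast clearance), three compounds have numbers so far:
compound 1 `C[C@@H]1CN(c2sc(C(F)(F)F)nc2-c2nc3cc(OCCO)ccc3[nH]2)CCN1C(=O)Cn1cnc2cccnc21` gives 43 mL.min-1.g-1;
compound 2 `C[C@@H]1CN(c2sc(C(F)(F)F)nc2-c2nc3ccccc3[nH]2)CCN1C(=O)Cn1cccn1` gives 44 mL.min-1.g-1;
compound 3 `Cc1nc(C)n(CC(=O)N2CCN(c3sc(C(F)(F)F)nc3-c3nc4ccc(C5CCOCC5)cc4[nH]3)C[C@H]2C)n1` gives 18 mL.min-1.g-1.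

Compound 3 stands lowest of the three, meaning the slowest clearance, and its gaps to compound 1 and to compound 2 both lie beyond the usual scatter of repeated measurements. Compound 4 `Cc1nc(C)n(CC(=O)N2CCN(c3sc(C(F)(F)F)nc3-c3nc4ccc(C5CCN(C)CC5)cc4[nH]3)C[C@H]2C)n1` differs from compound 3 in a single place: 1-methylpiperidin-4-yl in place of oxan-4-yl on an aromatic carbon. Going by the values given here, no pair of measured compounds shows a change of this kind, so nothing here tells how it should move the read-out. The expected step is a 1.2-fold higher number from compound 3 to compound 4 (0.09 log units; within the scatter), most likely none beyond the scatter, with real uncertainty either way. Compound 4 is therefore estimated at 22 mL.min-1.g-1, within a range from 9 mL.min-1.g-1 to 55 mL.min-1.g-1.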

Compound 4, intrinsic clearance in microsomes in the Homo sapiens assay: 27 mL.min-1.g-1
Compound 4: middle estimate off by 1.2-fold (0.09 log units), on the low side; low and high end bracket the measured number.
By their numbers in the Homo sapiens assay, from the lowest: compounds 3, 4, 1 and 2 (each within the scatter of the next, the first and the last beyond it).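

In the Homo sapiens assay, 1-methylpiperidin-4-yl in place of oxan-4-yl on an aromatic carbon gives a 1.5-fold higher number from compound 3 to compound 4 (0.18 log units; within the scatter), so at this position the exchange of one six-membered ring for the other shifts clearance by no more than the scatter. In a physicochemical assay for solubility, in simulated intestinal fluid (on this read-out lower numbers stand for lower solubility and higher numbers for higher solubility), compound 3 gives > 1000 ug/mL, which is a limit of the assay and not a number. In the physicochemical assay compound 4 gives > 1020 ug/mL, also a limit, so the step between the two cannot be read.

Still open, going by these compounds, is whether a carboxylic acid or a plain piperidin-4-yl at this aromatic carbon would move clearance beyond the scatter.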